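Aryl exchange on the shared core: estimate for compound 3

The compounds below may be only part of what the source reports. "The series", "measured", "known", "first", "only" and "open" are said of these compounds alone.

Measured compounds:
compound 1, `Cc1cc(NC(=O)Cn2nnc(-c3ccccn3)n2)n(C2CCCCC2)n1`, 81%
compound 2, `COc1ccc(-c2nnn(CC(=O)Nc3cc(C)nn3C3CCCCC3)n2)cc1`, 90%

In an assay on HEK293 cells for activation of Kir3.1/Kir3.2 (Homo sapiens), read by thallium flux (on this read-out lower numbers stand for smaller maximal responses and higher numbers for larger maximal responses), compound 2 gives 90%, the higher of the two numbers recorded; its nearest neighbour is compound 1, and the step of a number 9 percentage points higher from compound 1 to compound 2 (within the scatter) is within the scatter, so no order between the two is claimed. Both carry the same core, the aryl group on the aromatic carbon being the only difference.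

Compound 3 is `Cc1cc(NC(=O)Cn2nnc(-c3cccc(C#N)c3)n2)n(C2CCCCC2)n1`, not yet measured. Its change from compound 2 is 3-cyanophenyl in place of 4-methoxyphenyl on an aromatic carbon. Among the compounds with values here, the one measured step that bears on this, a number 9 percentage points higher from compound 1 to compound 2 (within the scatter), exchanges one aryl group for another at the same position and stays within the scatter. Nothing measured separates a 3-cyanophenyl from the groups already tried, so a step of similar size, in either direction or none beyond the scatter, is the expectation for this assay.

Compound 3 is therefore estimated at 83% in this assay, with a range of 66% to 96%, the expected step being a number 7 percentage points lower from compound 2 to compound 3 (within the scatter).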

Compound 3, largest response reached (Emax), in percent of the reference or control that the assay uses: 80%
Beside the measured number, compound 3's estimate is 3 percentage points above it; measured number inside the range.
By their numbers in this assay, from the lowest: compounds 3, 1 and 2 (each within the scatter of the next).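

In this assay, the aromatic carbon of the five-membered aromatic ring with 4 nitrogen has now carried three different aryl groups without any order appearing among them: the exchange for 3-cyanophenyl gives a number 10 percentage points lower from compound 2 to compound 3 (within the scatter), and against pyridin-2-yl it gives a number 1 percentage points lower from compound 1 to compound 3 (within the scatter). The earlier pair showed this only for pyridin-2-yl and 4-methoxyphenyl, whereas compound 3 at 80% extends the same picture to a phenyl ring bearing a nitrile, so that a nitrogen-containing substituent on the ring can take the place of an oxygen-containing one with the largest response staying within the scatter. No supporting evidence bears on this result, and the series offers no account of it.

Still open, on these data alone, is whether this tolerance extends beyond aryl groups at this position, for example to an amine, a carboxylic acid or a longer alkyl chain. Also open, as far as these compounds go, is whether the nitrile gives the same result as 4-cyanophenyl, and whether the largest response alone reflects how these compounds compare in concentration needed for activation.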